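The source may report more compounds than this note shows. Statements on the series, on what has been measured and on what is new or still open speak of the compounds shown alone.

In a toxicity assay on NIH3T3 cells (Mus musculus) for cytotoxicity, read by resazurin assay (on this read-out higher numbers stand for an effect only at larger amounts of compound and lower numbers for an effect already at smaller amounts), compound 1 `O=C(c1ccc(NCc2cncn2Cc2ccc(-c3ccccc3)cc2)cc1-c1ccccc1)N1CCCCC1` gives > 1000 nM, which is a limit. Compound 2 `c1ccc(-c2ccc(Cn3cncc3CNc3ccc(-c4ccccc4)c(-c4ccccc4)c3)cc2)cc1` gives > 10000 nM, also a limit, and so stands at the limit of > 10000 nM in this assay, at which 2 of the 3 values shown sit. Compound 3 `O=C(OC1CCCCC1)c1ccc(NCc2cncn2Cc2ccc(-c3ccccc3)cc2)cc1-c1ccccc1` gives > 10000 nM, again a limit.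

Compound 4 `c1ccc(-c2ccc(Cn3cncc3CNc3ccc(-c4ccccc4)cc3)cc2)cc1` differs from compound 2 by hydrogen in place of phenyl on an aromatic carbon. The nearest evidence is a step that the two limits leave unreadable from compound 1 to compound 2 and a step that the two limits leave unreadable from compound 2 to compound 3, and neither step removes this phenyl. No readable step size therefore bears on the change in this assay, and no direction can be drawn from these data. The expected step that the limit leaves unreadable from compound 2 to compound 4 lies within the scatter. Compound 4 is estimated at 12000 nM, with an expected range of 4000 nM to 40000 nM.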

Compound 4, half-maximal effective concentration: > 10000 nM
Compound 4 ended at the assay's limit; the forecaster's own chance of this, stated with the estimate: 60%; the middle value does not contradict the limit.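

Compound 2 and compound 4 both rest on a limit, and the step between them cannot be read. The compounds shown leave open whether hydrogen in place of phenyl changes the cytotoxicity read-out at all, and in which direction.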